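A few compounds are considered here, and "the series" means these few. Any claim that something is new, unique, unknown or untested is made for them only; others in the source may bear on it.

Compound 1 `O=C(CSc1nc2ccc(NC(=O)c3ccccc3)cc2s1)NCc1ccc(Cl)cc1` gives 30100 nM in a functional assay on HepG2 cells (Homo sapiens) for cytotoxicity, read by MTT assay, with a stated time of 48 h (on this read-out lower numbers stand for stronger inhibition and higher numbers for weaker inhibition), and its number and that of compound 2 `O=C(CSc1nc2ccc(NC(=O)c3ccccc3)cc2s1)NCc1ccccc1`, which gives 34200 nM in this assay, lie within the scatter of each other, the step of a 1.1-fold higher number from compound 1 to compound 2 (0.06 log units; within the scatter) being small. Compound 3 `O=C(CSc1nc2ccc(NC(=O)CCl)cc2s1)NCc1ccc(Cl)cc1` differs from compound 1 by chloromethyl in place of phenyl on a carbonyl carbon. Within the data shown here, no measured step touches the carbonyl carbon, so none of the measured steps bears directly on this change. The number for compound 3 is estimated at 18000 nM, within a range of 5000 nM to 60000 nM. The step of a 1.7-fold lower number from compound 1 to compound 3 (0.22 log units; within the scatter) is expected to stay near the scatter.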

Compound 3, half-maximal inhibitory concentration: 1800 nM
Compound 3: the middle estimate sits 10-fold (1.00 log units) above what was measured; the measured number lies below the stated range.
By their numbers in this assay, from the lowest: compound 3; then compounds 1 and 2 (each within the scatter of the next).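

Putting chloromethyl in place of phenyl on a carbonyl carbon gives a 17-fold lower number from compound 1 to compound 3 (1.22 log units; beyond the scatter) in this assay, so this position, unlike the aromatic carbon that carries the chloro group, can move the number beyond the scatter. That earlier change gave only a 1.1-fold higher number from compound 1 to compound 2 (0.06 log units; within the scatter). No evidence shown here accounts for the larger step. The compounds shown leave open whether the step follows from the chlorine of chloromethyl or from the loss of phenyl. A methyl, a bromomethyl or a longer chain on that carbonyl carbon would bear on this.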